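Cytotoxicity of a pyrazole carboxamide series: hydroxy to amino

The source may report more compounds than this note shows. Statements on the series, on what has been measured and on what is new or still open speak of the compounds shown alone.

Compound 1 `CC(C)Cc1nn(-c2cccc(F)c2)cc1C(=O)NCc1ccccc1`: 85900 nM
Compound 2 `CC(C)Cc1nn(-c2nccs2)cc1C(=O)NCc1ccc(O)cc1`: > 100000 nM
Compound 3 `CCOC(=O)c1cn(-c2ccc(OC)cc2)nc1CC(C)C`: 77100 nM

Of the compounds shown here, three on the shared core have been tested in a toxicity assay on HepG2 2.2.15 cells (Homo sapiens) for cytotoxicity, read by CCK-8 assay, with a stated time of 8 days; a higher number here means that more compound is tolerated, a lower number that less compound is tolerated. Compound 1 gives 85900 nM and compound 3 gives 77100 nM in this assay. For compound 2 this assay reports only a limit, > 100000 nM, so no number is known for it (the limit of > 100000 nM in this assay, at which 1 of the 3 values shown sits). Compound 4 `CC(C)Cc1nn(-c2nccs2)cc1C(=O)NCc1ccc(N)cc1` differs from compound 2 in one place: amino in place of hydroxy on an aromatic carbon. For the measured compounds named here, no measured pair isolates this change, so no size or direction of step can be read off for it in this assay; none beyond the scatter is expected. Compound 4 is therefore estimated at 100000 nM, within 50000 nM to 200000 nM, a step of a number no higher from compound 2 to compound 4 (the limit leaves the size open) expected to be within the scatter.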

Compound 4, half-maximal cytotoxic concentration: > 100000 nM
Compound 4: no number, only a limit; the forecaster's own chance of this, stated with the estimate: 55%; the middle value lies on the limit itself.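

In this assay, for the compounds shown here, compound 2 and compound 4 both carry only limits, so no step between them can be read. The compounds shown leave open what amino in place of hydroxy on an aromatic carbon changes in tolerated concentration, with a limit on each side: the limit of > 100000 nM in this assay, at which 2 of the 4 values shown sit.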